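The source may hold more compounds than are shown below. What is called first, only, known or untested is meant among the compounds shown, and "the series" means these compounds.

Compound 3, `CN(C)c1ccc(C2CC(c3ccc(-n4cncn4)cc3)=NN2C(=O)CCCl)cc1`, gives -0.7% in a functional assay on NCI-H1975 cells (Homo sapiens) for inhibition, read by sulforhodamine B assay, tested at 10 uM (on this read-out higher numbers stand for more inhibition at the one concentration tested (going by the name of the read-out) and lower numbers for less inhibition), the lowest of the three numbers shown, yet its distances to compound 2, `CN1CCN(c2ccc(C3=NN(C(=O)CCCl)C(c4ccc(N(C)C)cc4)C3)cc2)CC1`, with -0.2%, and to compound 1, `CN(C)c1ccc(C2CC(c3ccc(-n4ccnc4)cc3)=NN2)cc1`, with 0.1%, both lie within the scatter. The step of a number 0.5 percentage points lower from compound 2 to compound 3 (within the scatter) is the only one measured across a single change, and it swaps a different group for the triazole than the change now in question. Compound 4, `CN(C)c1ccc(C2CC(c3ccc(-n4ccnc4)cc3)=NN2C(=O)CCCl)cc1`, differs from compound 3 by 1H-imidazol-1-yl in place of 1H-1,2,4-triazol-1-yl on an aromatic carbon. Among the measured compounds shown here, no measured step touches this exact exchange; compound 1 carries the same imidazole as compound 4 but without the acyl group on the hydrazine nitrogen, and its number sits as close to zero as the others. Because compound 3 gives -0.7% and the other two values also cluster at the bottom of the assay's scale, the author expects the step of a number 1.2 percentage points higher from compound 3 to compound 4 (within the scatter) to stay within the scatter. Compound 4 is therefore estimated at 0.5%, with a range from -8% to 9%.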

Compound 4, a percentage reported as inhibition, at one concentration (the size of the read-out at that concentration, not a potency): -2.5%
Compound 4: the middle estimate sits 3 percentage points above what was measured; low and high end bracket the measured number.
By their numbers in this assay, from the lowest: compounds 4, 3, 2 and 1 (each within the scatter of the next).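

In this assay, among the compounds shown here, the exchange of 1H-1,2,4-triazol-1-yl for 1H-imidazol-1-yl on an aromatic carbon, para to a large group, gives a number 1.8 percentage points lower from compound 3 to compound 4 (within the scatter), the first direct reading of this swap, and it does not separate the two groups. The exchange of 4-methylpiperazin-1-yl for 1H-imidazol-1-yl at the same place gives a number 2.3 percentage points lower from compound 2 to compound 4 (within the scatter), so none of the three groups read at this position stands apart from the others. With the imidazole held constant, (2-chloroethyl)carbonyl in place of hydrogen on the ring amine nitrogen gives a number 2.6 percentage points lower from compound 1 to compound 4 (within the scatter), so this acyl group does not set the two compounds apart either.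

No outside measurement bears on these numbers. From the compounds shown here alone, whether a carboxylic acid or a primary amine on that aromatic carbon would lift the number clear of the scatter remains open.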